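The compounds below may be only part of what the source reports. "The series", "measured", "known", "first", "only" and "open" are said of these compounds alone.

Measured so far in a physicochemical assay for lipophilicity, read by HPLC; a lower number here means a more polar compound, a higher number a more lipophilic compound
compound 1 (`C[C@@H]1C[C@H]1C(=O)N1CCN(c2nc(-c3cnn(C)c3)ncc2C#N)C[C@H]1C`) 1.9
compound 2 (`C[C@@H]1CN(c2nc(-c3cnn(C)c3)ncc2C#N)CCN1C(=O)C1CC1`) 1.5
compound 3 (`CC1CC1C(=O)N1CCN(c2nc(-c3cnn(C)c3)ncc2C#N)C[C@H]1C`) 2

Compound 3 stands level with compound 1 (a number 0.10 log units higher from compound 1 to compound 3 (within the scatter)) and clearly apart from compound 2 (a number 0.50 log units higher from compound 2 to compound 3 (beyond the scatter)). In compound 4 (`CCC(=O)N1CCN(c2nc(-c3cnn(C)c3)ncc2C#N)C[C@H]1C`), ethyl takes the place of 2-methylcyclopropyl on a carbonyl carbon (ethyl in place of 2-methylcyclopropyl on a carbonyl carbon). Among the compounds with values here, no measured step covers this exact change. Within the data shown here, the closest guides are the two steps that add or remove the methyl on the saturated ring: the one above to compound 3, and the other (a number 0.40 log units lower from compound 1 to compound 2 (beyond the scatter)). A modest fall in this assay of similar size or slightly more is therefore expected (a number 0.60 log units lower from compound 3 to compound 4 (beyond the scatter)). For compound 4 the estimated value is 1.4 (expected range 1.1 to 1.7).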

Compound 4, distribution coefficient: 1.4
The estimate for compound 4 equals the measured number at the digits printed; the measured number falls inside the stated range.
By their numbers in this assay, from the lowest: compounds 4 and 2 (each within the scatter of the next); then compounds 1 and 3 (each within the scatter of the next).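

In (this assay), ethyl in place of 2-methylcyclopropyl on a carbonyl carbon now gives a direct reading (a number 0.60 log units lower from compound 3 to compound 4 (beyond the scatter)) and a matching one from the other methylated compound (a number 0.50 log units lower from compound 1 to compound 4 (beyond the scatter)). Ethyl and cyclopropyl at this place cannot be told apart (a number 0.10 log units lower from compound 2 to compound 4 (within the scatter)), so among these compounds only the 2-methylcyclopropyl group stands apart. Whether a longer chain or an amine on the carbonyl carbon would stay level with ethyl remains open, and nothing at hand bears on the cause of these steps.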